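The compounds below may be only part of what the source reports. "The series", "measured", "known", "first", "only" and "open" are said of these compounds alone.

Three compounds have been measured in a functional assay on CCRF-CEM cells (Homo sapiens) for inhibition, read by cell counting, with a stated time of 3 days; a lower number here means a stronger inhibitor, a higher number a weaker inhibitor:

compound 1, `C=C(Br)C(=O)Nc1cccc(-c2cn3nc(-c4ccc(C)cc4)sc3n2)c1`: 1700 nM
compound 2, `COc1ccc(-c2csc3nc(-c4cccc(N)c4)cn23)cc1`: 6100 nM
compound 3, `CCc1ccc(-c2nn3cc(-c4cccc(N)c4)nc3s2)cc1`: 22000 nM

Among these three, compound 1 gives the lowest number and is the strongest inhibitor of the set in this assay. Its nearest neighbour is compound 2, whose number lies higher by more than the usual scatter, and compound 3 lies furthest away, also well beyond the scatter. Within the data shown here, no two of the measured compounds differ in only one place, so no single step between them can be read off.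

The compound now in question is compound 4, `C=C(Br)C(=O)Nc1cccc(-c2cn3nc(-c4cccc(OC)c4)sc3n2)c1`. It is derived from compound 1 by one change: 3-methoxyphenyl in place of 4-methylphenyl on an aromatic carbon. Among the measured compounds shown here, nothing among the measured compounds isolates this exchange, so the size of the step in this assay can only be judged loosely. With no guide from the data, a small step is expected, either way, and most likely within or only a little beyond the scatter. Compound 4 is therefore estimated at 2500 nM, within a range from 800 nM to 8000 nM, which is expected to mean a step of a 1.5-fold higher number from compound 1 to compound 4 (0.17 log units; within the scatter).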

Compound 4, half-maximal inhibitory concentration: 1200 nM
Beside the measured number, compound 4's estimate is 2.1-fold (0.32 log units) above it, and the stated range covers the measured number.
By their numbers in this assay, from the lowest: compounds 4 and 1 (each within the scatter of the next); then compound 2; then compound 3.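

In this assay, 3-methoxyphenyl in place of 4-methylphenyl, on the aromatic carbon next to the ring nitrogen and next to the ring sulfur, gives a 1.4-fold lower number from compound 1 to compound 4 (0.15 log units; within the scatter), so compound 1 and compound 4 cannot be told apart. Among these compounds, this is the first step in the set that can be read at a single place, and it shows that this exchange, which alters both the group on the phenyl ring and where that group stands, leaves the number within the scatter. For this one pair, then, the assay does not register the exchange, although a single step says nothing about how other groups at this place would read. No measurement is at hand that could explain this result.

On these data alone, it remains open whether 3-methylphenyl or 4-methoxyphenyl on the core of compound 1 would also stay within the scatter, which would help separate the identity of the group from its place on the phenyl ring. As far as these compounds go, it is equally open how a group of another kind at this place, such as an amine, a carboxylic acid or a longer alkyl chain on the phenyl ring, would read in this assay.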